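The compounds below may be only part of what the source reports. "The series", "measured", "known", "first", "only" and "open" are said of these compounds alone.

Measured so far:
compound 1 `Cc1[nH]c2ccc([N+](=O)[O-])cc2c1C1(c2c(C)[nH]c3ccc([N+](=O)[O-])cc23)C(=O)Nc2ccccc21`: 99400 nM
compound 2 `O=C1Nc2ccc(Cl)cc2C1(c1c[nH]c2ccc(Br)cc12)c1c[nH]c2ccc(Br)cc12`: > 100000 nM
compound 3 `Cc1[nH]c2ccc([N+](=O)[O-])cc2c1C1(c2c(C)[nH]c3ccc([N+](=O)[O-])cc23)C(=O)Nc2ccc(Cl)cc21`: 10100 nM

In a functional assay on MDA-MB-231 cells (Homo sapiens) for cytotoxicity, read by MTT assay, with a stated time of 48 h (on this read-out lower numbers stand for stronger inhibition and higher numbers for weaker inhibition), compound 3 gives 10100 nM and compound 1 gives 99400 nM. Compound 2 reaches only (the limit of > 100000 nM in this assay, at which 1 of the 3 values shown sits), so its value is a limit and not a number. How the core of compound 2 differs from the core of compound 3 is not broken down here. From compound 3 to compound 1 the change is hydrogen in place of chloro on an aromatic carbon, and it gave a 9.8-fold higher number from compound 3 to compound 1 (0.99 log units; beyond the scatter).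

Compound 4 `O=C1Nc2ccccc2C1(c1c[nH]c2ccc(Br)cc12)c1c[nH]c2ccc(Br)cc12` is not yet measured. It differs from compound 2 by hydrogen in place of chloro on an aromatic carbon, the same change at the same place. Because the measured step of a 9.8-fold higher number from compound 3 to compound 1 (0.99 log units; beyond the scatter) ran toward a higher number, the step from compound 2 to compound 4 is expected to be a step that the limit leaves unreadable from compound 2 to compound 4. Compound 4 is therefore estimated at 300000 nM in this assay, most probably reported again only as a limit.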

Compound 4, half-maximal inhibitory concentration: 9950 nM
The estimate for compound 4 lay 30-fold (1.48 log units) above the measured number; the measured number lies below the stated range.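

In this assay compound 2 stands at > 100000 nM, which is a limit and not a number. Hydrogen in place of chloro on an aromatic carbon gave an at least 10-fold lower number from compound 2 to compound 4 (1.00 log units; beyond the scatter), so the change does not carry from one core to the other with the same direction: the same change on two cores in this assay, a 9.8-fold higher number (0.99 log units; beyond the scatter) from compound 3 to compound 1 and an at least 10-fold lower number (1.00 log units; beyond the scatter) from compound 2 to compound 4, at least 98-fold (1.99 log units) apart, beyond the scatter of two such steps. Within the data shown here, this rests on only two pairs; it shows that the outcome of the change differs between these two cores, but not which difference between them is responsible, and the limit leaves the full size of the new step unknown.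

Still open, going by these compounds, is whether the nitro and methyl groups of one core or the bromo groups of the other govern the direction of the step. Also open, on these data alone, is how an amine or a methoxy group in place of the chloro would behave on either core.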